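The source may report more compounds than this note shows. Statements on the series, on what has been measured and on what is new or still open speak of the compounds shown alone.

Of the compounds shown here, three with a shared core have been tested in an ADME assay on MT4 cells (Homo sapiens) for cytotoxicity, read by MTT assay, with a stated time of 4 days; on this read-out lower numbers stand for higher toxicity in this test and higher numbers for lower toxicity in this test. Compound 1 `Cc1c(Cc2c(F)cccc2F)nc(N(C)C)[nH]c1=O` gives > 89000 nM, which is a limit and not a number. Compound 2 `CCCN(C)c1nc(Cc2c(F)cccc2F)c(C)c(=O)[nH]1` gives > 81000 nM, also a limit. Compound 3 `Cc1c(Cc2c(F)cccc2F)nc(N(C)C2CCCCC2)[nH]c1=O` gives > 72000 nM, again a limit, so it has no exact value to start from. Compound 4 `Cc1c(Cc2c(F)cccc2F)nc(N(C)c2ccccc2)[nH]c1=O` carries phenyl in place of cyclohexyl on a nitrogen on an aromatic ring. Among the measured compounds shown here, the steps that bear on this change are a step that the two limits leave unreadable from compound 1 to compound 3 and a step that the two limits leave unreadable from compound 2 to compound 3, along with a step that the two limits leave unreadable from compound 1 to compound 2. None of them has a readable size, so no step beyond the usual scatter is expected in this assay. The expected change is an at least 1.0-fold lower number from compound 3 to compound 4 (0.01 log units; that floor lies within the scatter). Compound 4 is estimated at 70000 nM, within an expected range of 25000 nM to 120000 nM.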

Compound 4, half-maximal cytotoxic concentration: > 73000 nM
Compound 4: no number, only a limit; the forecaster's own chance of this, stated with the estimate: 75%; middle value at least 1.0-fold (0.01 log units) away from the limit.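

Among the compounds shown here, compound 1, compound 2, compound 3 and compound 4 all give limits and not numbers, so no step between them can be read. The compounds shown leave open whether methyl, propyl, cyclohexyl or phenyl on that nitrogen changes the toxicity read-out at all.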